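This account rests on a few compounds, and the source may have more. Where it says the series, first, only, none or still open, it means among the compounds named here.

Compound 1 `O=C(Nc1nn[nH]n1)c1cccc(-c2ccccc2)n1`: 81%
Compound 2 `Cc1cc(C(=O)Nc2nn[nH]n2)nc(-c2ccccc2)c1`: 88%
Compound 3 `CCCc1cc(C(=O)Nc2nn[nH]n2)nc(-c2ccccc2)c1`: 85%

All three were tested in a functional assay on the whole organism for inhibition, with Rattus norvegicus as the target, at a dose of 10 mg/kg by the oral route; on this read-out lower numbers stand for a weaker effect and higher numbers for a stronger effect at the one dose given. The step of a number 7 percentage points higher from compound 1 to compound 2 (within the scatter), the step of a number 4 percentage points higher from compound 1 to compound 3 (within the scatter) and the step of a number 3 percentage points lower from compound 2 to compound 3 (within the scatter) all sit within the scatter, so the three values cannot be ranked. Compound 4 `CCCc1cc(C(=O)Nc2nn[nH]n2)nc(-c2ccc(C)cc2)c1` has not yet been measured. It differs from compound 3 by methyl in place of hydrogen on an aromatic carbon. The same kind of change, (methyl in place of hydrogen on an aromatic carbon), links compound 1 and compound 2, where it gave a number 7 percentage points higher from compound 1 to compound 2 (within the scatter). The two cores differ by propyl in place of hydrogen on an aromatic carbon. The surroundings are not the same: in compound 2 the methyl sits on a six-membered aromatic ring with 1 nitrogen, meta to a group of 8 heavy atoms, meta to a phenyl group and opposite the ring nitrogen, whereas in compound 4 it sits on a six-membered aromatic ring of carbon only, para to a large group. For compound 4 a step of a number 1 percentage points higher from compound 3 to compound 4 (within the scatter) in this assay is expected. That expectation rests on the earlier step of a number 7 percentage points higher from compound 1 to compound 2 (within the scatter) staying within the scatter. Compound 4 is therefore estimated at 86%, between 72% and 95%.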

Compound 4, a percentage reported as inhibition, in the whole organism at one dose (the size of the read-out at that dose, not a potency): 84%
Compound 4: middle estimate off by 2 percentage points, on the high side; the measured number falls inside the stated range.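

In this assay, methyl in place of hydrogen on an aromatic carbon, here phenyl to 4-methylphenyl, gave a number 1 percentage points lower from compound 3 to compound 4 (within the scatter). Set beside the earlier case of this change, the two steps do not differ: the same change on two cores in this assay, a number 7 percentage points higher (within the scatter) from compound 1 to compound 2 and a number 1 percentage points lower (within the scatter) from compound 3 to compound 4, 8 percentage points apart, within the scatter of two such steps. This shows that, at this one dose, nothing separates the outcome of the change on the two cores, but it does not show that methyl has any effect on either core, nor that the two steps would match on other cores.

The compounds shown leave open whether a chlorine, a methoxy or a carboxylic acid on that same phenyl ring would give a step beyond the scatter. They also leave open what a longer chain in place of propyl would give.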